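A few compounds are considered here, and "the series" means these few. Any claim that something is new, unique, unknown or untested is made for them only; others in the source may bear on it.

In a functional assay on CHO-K1 cells for agonist activity at Glucose-dependent insulinotropic receptor (Homo sapiens), read by a luciferase reporter, with a stated time of 5 h (a lower number here means that less compound is needed, a higher number that more compound is needed for the effect), compound 2 `CCCCOC(=O)N1CCC(Oc2ncnc3c2CCN3c2ccc(S(C)(=O)=O)cc2F)CC1` gives 50.1 nM, the lowest number among the three compounds measured. Compound 1 `CC(C)OC(=O)N1CCC(Oc2ncnc3c2CCN3c2ccc(-c3cccn3C)cc2F)CC1` gives 158 nM in this assay, and compound 3 `N#CN1CCC(O)CC1` gives 316 nM; both gaps from compound 2 lie beyond the usual scatter of repeated measurements, so compound 2 needs the least material for the effect here. The compound not yet measured is compound 4 `CC(C)c1noc(N2CCC(Oc3ncnc4c3CCN4c3ccc(S(C)(=O)=O)cc3F)CC2)n1`. It differs from compound 2 in one place: 3-isopropyl-1,2,4-oxadiazol-5-yl in place of butoxycarbonyl on an amine nitrogen in a ring. The ring that bears the group, its link to the shared core and everything else stay the same. For the measured compounds named here, no pair of measured compounds shows an exchange of this kind, so nothing in the numbers tells how the swap of an open-chain butoxycarbonyl for a five-membered aromatic ring with 3 hetero atoms will shift the result. Without such a step to rest on, the change from compound 2 to compound 4 is expected to be small, a 1.1-fold lower number from compound 2 to compound 4 (0.05 log units; within the scatter), within the scatter in either direction. Compound 4 is estimated at 45 nM, with a range from 12 nM to 160 nM.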

Compound 4, half-maximal effective concentration: 79.4 nM
Compound 4: middle estimate off by 1.8-fold (0.25 log units), on the low side; the measured number falls inside the stated range.
By their numbers in this assay, from the lowest: compounds 2, 4, 1 and 3 (each within the scatter of the next, the first and the last beyond it).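

In this assay, the amine nitrogen in the six-membered ring can carry 3-isopropyl-1,2,4-oxadiazol-5-yl in place of butoxycarbonyl, with a 1.6-fold higher number from compound 2 to compound 4 (0.20 log units; within the scatter). For this pair, then, an open chain with a carbonyl is not required for a number in this range, since a five-membered aromatic ring with 3 hetero atoms on the same nitrogen cannot be told apart from it in this assay. Nothing measured here explains why the two groups read alike.

The compounds shown do not separate the part played by the ring from that of its isopropyl group, which a cyclopropyl, a tert-butyl or a plain methyl on the same ring could test. They also leave open whether a different ring on this nitrogen, such as a pyrimidine, or a simple acetyl group would fit equally well.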